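This account rests on a few compounds, and the source may have more. Where it says the series, first, only, none or still open, it means among the compounds named here.

Compound 1 `Cn1ncc(Cl)c1-c1cc(C(=O)N[C@@H]2CN[C@H](CC(=O)O)C[C@H]2c2ccc(Cl)c(Cl)c2)oc1Cl` gives 4020 nM in a functional assay on HCT-116 cells (Homo sapiens) for antiproliferative activity, read by sulforhodamine B assay, with a stated time of 72 h (a higher number here means a weaker inhibitor, a lower number a stronger inhibitor), the highest of the three numbers: compound 3 `Cn1ncc(Cl)c1-c1cc(C(=O)N[C@@H]2CN[C@H](CCNS(C)(=O)=O)C[C@H]2c2ccc(F)c(F)c2)oc1Cl` gives 920 nM and compound 2 `Cn1ncc(Cl)c1-c1cc(C(=O)N[C@@H]2CN[C@H](CC(O)CO)C[C@H]2c2ccc(F)c(F)c2)oc1Cl` gives 800 nM, both beyond the scatter below compound 1. Compound 4 `CCC[C@@H]1C[C@@H](c2ccc(Cl)c(Cl)c2)[C@H](NC(=O)c2cc(-c3c(Cl)cnn3C)c(Cl)o2)CN1` differs from compound 1 by ethyl in place of carboxy on a saturated chain carbon bound to a saturated ring carbon. For the measured compounds named here, no measured step covers this change; the one step within the set, a 1.2-fold higher number from compound 2 to compound 3 (0.06 log units; within the scatter), swaps two chains that both lack the carboxy and shows no movement. Compounds 2 and 3 also differ from compound 1 in the halogens on the phenyl ring, so their lower numbers are not a clean comparison. A modest lower number is expected for compound 4, a 2.2-fold lower number from compound 1 to compound 4 (0.35 log units; beyond the scatter), giving an estimate of 1800 nM with a range of 500 nM to 6000 nM.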

Compound 4, half-maximal inhibitory concentration: 1020 nM
Estimate against measurement, compound 4: 1.8-fold (0.25 log units) above, within the range that was stated.
By their numbers in this assay, from the lowest: compounds 2, 3 and 4 (each within the scatter of the next); then compound 1.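

With the rest of the structure unchanged, ethyl in place of carboxy in this assay gives a 3.9-fold lower number from compound 1 to compound 4 (0.60 log units; beyond the scatter). For the compounds shown here, this is the first comparison at this position with the phenyl halogens held constant, and it shows that activity here does not require the carboxy. No measured data bear on the reason for this step.

Still open, on these data alone, is how an amine, a primary amide or a longer alkyl chain such as butyl would read at this place. Also open, as far as these compounds go, is whether the step carries over to the difluorophenyl compounds.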